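Lengthening the Ether Chain in a Cyclopropane Hydrazide Series

The compounds below may be only part of what the source reports. "The series", "measured", "known", "first", "only" and "open" are said of these compounds alone.

Compound 1 `COc1ccc(C2CC2C(=O)NNc2nncc3ccccc23)cc1`: 72000 nM
Compound 2 `O=C(NNc1nncc2ccccc12)C1CC1c1ccc(OC(F)(F)F)cc1`: 54000 nM
Compound 3 `CCOc1ccc(C2CC2C(=O)NNc2nncc3ccccc23)cc1`: "not determined" (no result reported)

In a functional assay on MCF7 cells (Homo sapiens) for inhibition, read by MTT assay, with a stated time of 72 h (a lower number here means a stronger inhibitor, a higher number a weaker inhibitor), compound 1 gives 72000 nM and compound 2 gives 54000 nM. One step sums up their difference: a 1.3-fold lower number from compound 1 to compound 2 (0.12 log units; within the scatter). Compound 3 differs from compound 1 only in the chain on the oxygen, but in this assay compound 3 gives "not determined" (no result reported), so it stands unplaced. Compound 4 `CC(C)=CCOc1ccc(C2CC2C(=O)NNc2nncc3ccccc23)cc1` differs from compound 3 by 2-methylprop-1-en-1-yl in place of methyl on a saturated chain carbon bound to an oxygen on an aromatic ring. Among the measured compounds shown here, no measured step alters this chain, so none bears directly on the change; the only measured step, a 1.3-fold lower number from compound 1 to compound 2 (0.12 log units; within the scatter), stayed within the scatter. Compound 4 is therefore expected to land near the two measured values, estimated at 60000 nM with a range from 15000 nM to 250000 nM.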

Compound 4, half-maximal inhibitory concentration: 69000 nM
Compound 4: the middle estimate sits 1.2-fold (0.06 log units) below what was measured, within the range that was stated.
By their numbers in this assay, from the lowest: compounds 2, 4 and 1 (each within the scatter of the next).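

Putting 3-methylbut-2-en-1-yl on the oxygen, a chain with a double bond, keeps the number in this assay within the scatter of both earlier compounds (a 1.0-fold lower number from compound 1 to compound 4 (0.02 log units; within the scatter)) (a 1.3-fold higher number from compound 2 to compound 4 (0.11 log units; within the scatter)). So methyl, trifluoromethyl and this far bigger group, with four more heavy atoms in the part that differs from the ethyl compound's chain end, all give readings that cannot be told apart here. Nothing measured on these compounds explains this result.

Compound 3, with its ethoxy group, remains unplaced. Going by these compounds, whether an amine or a carboxylic acid in place of these chains would shift the number stays open.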